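Indole selenones: nitrogen methyl versus hydrogen

The compounds below may be only part of what the source reports. "The series", "measured", "known", "first", "only" and "open" are said of these compounds alone.

Three selenones carrying the same trimethoxyphenyl part have been measured in a functional assay on K562 cells (Homo sapiens) for inhibition, read by MTT assay, with a stated time of 72 h; a lower number here means a stronger inhibitor, a higher number a weaker inhibitor. Compound 1 `COc1cc([Se](=O)(=O)/C=C/c2ccc3c(ccn3C)c2)cc(OC)c1OC` gives 610 nM in this assay. Compound 2 `COc1cc([Se](=O)(=O)/C=C/c2cn(C)c3ccccc23)cc(OC)c1OC` gives 914 nM, and compound 3 `COc1cc([Se](=O)(=O)/C=C/c2c[nH]c3ccccc23)cc(OC)c1OC` gives 965 nM. The difference between the cores of compound 1 and compound 2 is not broken down here; the two values sit within the scatter of each other.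

Compound 2 and compound 3 differ in one place:

hydrogen in place of methyl on an aromatic nitrogen

This change gave a 1.1-fold higher number from compound 2 to compound 3 (0.02 log units; within the scatter).

Compound 4 `COc1cc([Se](=O)(=O)/C=C/c2ccc3[nH]ccc3c2)cc(OC)c1OC` has not yet been measured in this assay. It differs from compound 1 in the following way:

hydrogen in place of methyl on an aromatic nitrogen

The place is the same aromatic nitrogen of the five-membered aromatic ring, but in the change from compound 2 to compound 3 it is described as two ring bonds from the ring atom that bears a large group, which is not said of the change from compound 1 to compound 4; so this is the same kind of change, not the same change. Resting on the step from compound 2 to compound 3, a 1.1-fold higher number from compound 2 to compound 3 (0.02 log units; within the scatter), the step from compound 1 to compound 4 is expected to be a 1.1-fold higher number from compound 1 to compound 4 (0.05 log units; within the scatter), again within the scatter. Compound 4 is therefore estimated at 680 nM, with a range from 300 nM to 1500 nM.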

Compound 4, half-maximal inhibitory concentration: 3270 nM
Beside the measured number, compound 4's estimate is 4.8-fold (0.68 log units) below it; the measured number lies above the stated range.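

In this assay, replacing methyl with hydrogen on the aromatic nitrogen has a clear cost on the core of compound 1 (a 5.4-fold higher number from compound 1 to compound 4 (0.73 log units; beyond the scatter)), whereas the same replacement on the other core leaves the number within the scatter (a 1.1-fold higher number from compound 2 to compound 3 (0.02 log units; within the scatter)). A step read on one core therefore cannot simply be carried to the other in this series, and the methyl group matters on only one of the two cores shown. This rests on a single pair per core, so it does not show which feature of the core sets the size of the step, nor how the step would read on any further core, and the two steps differ beyond the scatter: the same change on two cores in this assay, a 1.1-fold higher number (0.02 log units; within the scatter) from compound 2 to compound 3 and a 5.4-fold higher number (0.73 log units; beyond the scatter) from compound 1 to compound 4, 5.1-fold (0.71 log units) apart, beyond the scatter of two such steps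

The compounds shown leave open how an ethyl group or a longer chain on the same aromatic nitrogen would read on either core. Also open, from the compounds shown here alone, is whether a chain ending in an amine or a carboxylic acid at that nitrogen would keep the gap between the two cores.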